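Dibromophenyl to dihydroxyphenyl on the amide nitrogen

The source may report more compounds than this note shows. Statements on the series, on what has been measured and on what is new or still open speak of the compounds shown alone.

Measured so far:
compound 1, `Cn1c(Cc2nn(C)c(=O)c3ccccc23)nnc1SCCCCCCCC(=O)Nc1ccc(Br)cc1Br`: 1500 nM
compound 2, `Cn1c(Cc2nn(C)c(=O)c3ccccc23)nnc1S(=O)(=O)CCCCCCCC(=O)Nc1ccc(Br)cc1Br`: 1400 nM

Both compounds were tested in an assay on isolated protein (Mus musculus) for inhibition of IL15-IL15 receptor (Homo sapiens), read by resazurin assay, with stated times of 30 min and 2.5 days; a higher number here means a weaker inhibitor, a lower number a stronger inhibitor. Compound 1 gives 1500 nM, the highest of the two numbers; compound 2 gives 1400 nM, and the gap between them lies within the scatter, so the two are read as equivalent.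

Compound 3, `Cn1c(Cc2nn(C)c(=O)c3ccccc23)nnc1SCCCCCCCC(=O)Nc1ccc(O)cc1O`, is built from compound 1 by one change on the amide-type nitrogen:

2,4-dihydroxyphenyl in place of 2,4-dibromophenyl on an amide-type nitrogen

Going by the values given here, no measured pair shows this change, so there is nothing to calibrate its size or direction against; the two values in hand only say that the rest of the molecule tolerates variation at a different site without moving the number. The step from compound 1 to compound 3 is expected to be modest, if anything toward a higher number, with a fair chance that it stays within the scatter: a 1.7-fold higher number from compound 1 to compound 3 (0.22 log units; within the scatter). Compound 3 is therefore estimated at 2500 nM, in a range from 700 nM to 9000 nM.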

Compound 3, half-maximal inhibitory concentration: 17000 nM
Beside the measured number, compound 3's estimate is 6.8-fold (0.83 log units) below it; the measured number lies above the stated range.
By their numbers in this assay, from the lowest: compounds 2 and 1 (each within the scatter of the next); then compound 3.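

In this assay, the substituent on the amide-type nitrogen matters in a way the earlier pair could not show: the change from 2,4-dibromophenyl to 2,4-dihydroxyphenyl gives an 11-fold higher number from compound 1 to compound 3 (1.05 log units; beyond the scatter). The aromatic ring and the count of 8 heavy atoms stay the same, while 2 bromine give way to 2 oxygen and 2 hydrogen-bond donors and 2 hydrogen-bond acceptors enter, so the step shows that this position does not accept every group of this size equally. Nothing available bears on the origin of this step.

On these data alone, whether one hydroxy group alone would give a step of this size remains open, as does the outcome of the same exchange on compound 2. Also open, as far as these compounds go, is whether 2,4-dichlorophenyl or 2,4-dimethoxyphenyl on the same nitrogen would stay close to compound 1.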